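Oxazole substituent changes in the phenylheptanoyl series

The source may report more compounds than this note shows. Statements on the series, on what has been measured and on what is new or still open speak of the compounds shown alone.

Three compounds share a core in which a phenylheptanoyl chain is attached to a five-membered heteroaromatic ring, and they differ only in the group carried on that ring. In an assay on HEK-293T cells for inhibition of diacylglycerol lipase-alpha (Homo sapiens), read by colorimetric assay (a higher number here means a weaker inhibitor, a lower number a stronger inhibitor), compound 1 `O=C(CCCCCCc1ccccc1)c1nc(C(F)(F)F)co1` gives 214 nM. Compound 2 `CN(C)C(=O)c1coc(C(=O)CCCCCCc2ccccc2)n1` gives 3390 nM in this assay, a move of a 16-fold higher number from compound 1 to compound 2 (1.20 log units; beyond the scatter). Compound 3 `O=C(CCCCCCc1ccccc1)c1nc(Br)co1` reaches only the limit of this assay, recorded as > 10000 nM; this is the same limit as the limit of > 10000 nM in this assay, at which 1 of the 3 values shown sits, and it is not a number. The steps to it are large: an at least 46-fold higher number from compound 1 to compound 3 (1.66 log units; beyond the scatter) and an at least 2.9-fold higher number from compound 2 to compound 3 (0.46 log units; beyond the scatter). Compound 3 therefore stands at the weak end of the measured set.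

Compound 4 `CSc1cnc(C(=O)CCCCCCc2ccccc2)o1` is the next case: 5-(methylsulfanyl)-1,3-oxazol-2-yl in place of 4-bromo-1,3-oxazol-2-yl on a carbonyl carbon. Within the data shown here, no measured step covers this change, since every measured step swaps one group for another at the same ring carbon, whereas here the group is removed from one ring carbon and a different group appears on another. Among the measured compounds shown here, the measured steps show only that the ring substituent moves this assay strongly in either direction. In this assay compound 4 is therefore expected at around 3000 nM, with a plausible range of 400 nM to 12000 nM, which corresponds to an expected step of an at least 3.3-fold lower number from compound 3 to compound 4 (0.52 log units; beyond the scatter).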

Compound 4, half-maximal inhibitory concentration: > 10000 nM
Compound 4: no number, only a limit (the forecaster's own chance of this, stated with the estimate: 30%); middle value at least 3.3-fold (0.52 log units) from the limit.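

Compound 3 and compound 4 are both recorded only as limits and not as numbers, so no step between them can be read in this assay: the limit of > 10000 nM in this assay, at which 2 of the 4 values shown sit.

Left open is how compound 3 and compound 4 rank against each other, and whether 5-(methylsulfanyl)-1,3-oxazol-2-yl in place of 4-bromo-1,3-oxazol-2-yl changes inhibition at all.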